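Replacing cyano with 1H-imidazol-1-yl on an aromatic ring

The source may hold more compounds than are shown below. What is called first, only, known or untested is meant among the compounds shown, and "the series" means these compounds.

Three close relatives, compound 1 `COC(=O)N[C@H](C(=O)NN(CCC[C@@](O)(Cc1ccccc1)C(=O)N[C@H]1c2ccccc2C[C@H]1O)Cc1ccc(Cl)cc1)C(C)(C)C`, compound 2 `COC(=O)N[C@H](C(=O)NN(CCC[C@](O)(Cc1ccccc1)C(=O)N[C@H]1c2ccccc2C[C@H]1O)Cc1ccc(Br)cc1)C(C)(C)C` and compound 3 `COC(=O)N[C@H](C(=O)NN(CCC[C@@](O)(Cc1ccccc1)C(=O)N[C@H]1c2ccccc2C[C@H]1O)Cc1ccc(C#N)cc1)C(C)(C)C`, have been tested in an ADME assay on MT4 cells (Homo sapiens) for cytotoxicity; on this read-out higher numbers stand for lower toxicity in this test and lower numbers for higher toxicity in this test. Compound 1 gives > 10000 nM, which is a limit of the assay and not a number. Compound 2 gives > 10000 nM, which is also a limit. Compound 3 gives > 10000 nM, again a limit, so it has no exact position on the scale.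

Compound 4 `COC(=O)N[C@H](C(=O)NN(CCC[C@@](O)(Cc1ccccc1)C(=O)N[C@H]1c2ccccc2C[C@H]1O)Cc1ccc(-n2ccnc2)cc1)C(C)(C)C` keeps the core of compound 3 but carries 1H-imidazol-1-yl in place of cyano on an aromatic carbon, para to a large group: 1H-imidazol-1-yl in place of cyano on an aromatic carbon.

For the measured compounds named here, one measured step bears on this change, since it falls on the same aromatic carbon: a step that the two limits leave unreadable from compound 1 to compound 3. It therefore offers no size to carry over. In this assay, no step beyond the usual scatter is expected, in either direction, because compounds 1, 2 and 3 all sit at the limit of > 10000 nM in this assay, at which 3 of the 3 values shown sit. The expected change is a step that the limit leaves unreadable from compound 3 to compound 4, and this is only an estimate. The result may well be reported as a limit again. For compound 4 the estimated value is 12000 nM, with an expected range from 5000 nM to 40000 nM.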

Compound 4, half-maximal cytotoxic concentration: > 10000 nM
Compound 4: only a limit was reported (the forecaster's own chance of this, stated with the estimate: 80%); the middle value lies beyond the limit too.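

In this assay compound 4 gives > 10000 nM, which is a limit of the assay and not a number. The steps to compound 4 from compound 3 and from compound 1 therefore cannot be read. Whether compound 1, compound 3 and compound 4 truly differ in this assay stays open, as the values shown reach no further than this: the limit of > 10000 nM in this assay, at which 4 of the 4 values shown sit.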